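The source may hold more compounds than are shown below. What is called first, only, known or untested is meant among the compounds shown, and "the series" means these compounds.

Of the compounds shown here, three sharing one core have been measured in an assay on CHO cells for displacement of a labelled ligand from prostaglandin E2 receptor EP3 subtype (Homo sapiens), read by radioligand binding; a lower number here means a stronger inhibitor, a higher number a weaker inhibitor. Compound 1 `CC(C)C(Nc1nnc[nH]1)c1ccc(-c2ccc3cccc(F)c3c2)[nH]c1=O` gives 22 nM, compound 2 `CC(C)C(Cc1nnc[nH]1)c1ccc(-c2ccc3cccc(F)c3c2)[nH]c1=O` gives 10 nM, and compound 3 `CC(C)C(c1cnc(N)s1)c1ccc(-c2ccc3cccc(F)c3c2)[nH]c1=O` gives 16 nM. For the measured compounds named here, compound 3 thus stands second highest of the three numbers, with a 1.4-fold lower number from compound 1 to compound 3 (0.14 log units; within the scatter) and a 1.6-fold higher number from compound 2 to compound 3 (0.20 log units; within the scatter) both small, while a 2.2-fold lower number from compound 1 to compound 2 (0.34 log units; beyond the scatter) is the only step beyond the scatter. Compound 4 `CC(C)C(/C=C1/CCNC1=O)c1ccc(-c2ccc3cccc(F)c3c2)[nH]c1=O` differs from compound 3 in one place: a group of 7 heavy atoms (5 carbon, 1 nitrogen, 1 oxygen; one five-membered non-aromatic ring with 1 hetero atom) in place of a group of 6 heavy atoms (3 carbon, 2 nitrogen, 1 sulfur; one five-membered aromatic ring with 2 hetero atoms), on a saturated chain carbon bound to an aromatic carbon and a saturated chain carbon. Going by the values given here, no measured step brings in a non-aromatic ring at this position, so the existing steps bear on it only indirectly; all three variations there give numbers within a narrow band. A change of about a 1.6-fold higher number from compound 3 to compound 4 (0.19 log units; within the scatter) is therefore expected, weakly toward a higher number, and compound 4 is estimated at 25 nM, ranging from 8 nM to 80 nM.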

Compound 4, inhibition constant: 5.3 nM
Compound 4: middle estimate off by 4.7-fold (0.67 log units), on the high side; measured number below the stated range.
By their numbers in this assay, from the lowest: compounds 4, 2, 3 and 1 (each within the scatter of the next, the first and the last beyond it).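

A ring need not be aromatic at this place in this assay: the non-aromatic five-membered ring with 1 hetero atom gives a 3.0-fold lower number from compound 3 to compound 4 (0.48 log units; beyond the scatter) and a 4.2-fold lower number from compound 1 to compound 4 (0.62 log units; beyond the scatter) against the thiazole and aminotriazole groups. Against the triazolylmethyl group it gives a 1.9-fold lower number from compound 2 to compound 4 (0.28 log units; within the scatter) and so cannot be set apart from it. No evidence is available on what lies behind these steps. As far as these compounds go, whether the ring carbonyl, the ring nitrogen or the exocyclic double bond carries the lower number stays open, as does how an open-chain amide or a carboxylic acid would behave here.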